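The compounds below may be only part of what the source reports. "The series", "measured", "known", "first", "only" and "open" are said of these compounds alone.

Of the compounds shown here, three sharing one core have been tested in a toxicity assay on MDCK cells (Canis lupus familiaris) for cytotoxicity, read by crystal violet staining, with a stated time of 48 h; on this read-out higher numbers stand for lower toxicity in this test and lower numbers for higher toxicity in this test. Compound 1 `Cc1ccc2[nH]c(=O)c(CN(Cc3ccc(OC(C)C)cc3)Cc3ccc(C(C)(C)C)cc3)cc2c1` gives > 5000 nM, which is a limit of the assay rather than a number. Compound 2 `CCCOc1ccc(CN(Cc2ccc(C(C)(C)C)cc2)Cc2cc3cc(C)ccc3[nH]c2=O)cc1` gives > 5000 nM, again a limit. Compound 3 `Cc1ccc2[nH]c(=O)c(CN(Cc3ccc(OC(F)(F)F)cc3)Cc3ccc(C(C)(C)C)cc3)cc2c1` gives > 5000 nM, also a limit. Compound 3 thus stands level with the other two as far as these numbers can tell. The three measured steps, a step that the two limits leave unreadable from compound 1 to compound 2, a step that the two limits leave unreadable from compound 1 to compound 3 and a step that the two limits leave unreadable from compound 2 to compound 3, cannot be read in size because the limit of > 5000 nM in this assay, at which 3 of the 3 values shown sit, covers both ends of each of them.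

Compound 4 `Cc1ccc2[nH]c(=O)c(CN(Cc3ccc(N(C)C)cc3)Cc3ccc(C(C)(C)C)cc3)cc2c1` differs from compound 3 by one change: dimethylamino in place of trifluoromethoxy on an aromatic carbon. Within the data shown here, none of the measured steps touches this change, and none has a readable size, so no step beyond the scatter in this assay is expected in either direction. The step expected is a step that the limit leaves unreadable from compound 3 to compound 4. Compound 4 is therefore expected to give about 8000 nM, within a range from 3000 nM to 30000 nM, and most likely to be reported once more as a limit.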

Compound 4, half-maximal cytotoxic concentration: > 5000 nM
Compound 4: a limit, no number; the forecaster's own chance of this, stated with the estimate: 80%; the middle value lies beyond the limit too.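

Compound 4 gives > 5000 nM in this assay, and this too is a limit. Its steps from compound 1, compound 2 and compound 3 cannot be read in size, because all four compounds sit at the same limit: the limit of > 5000 nM in this assay, at which 4 of the 4 values shown sit. The compounds shown leave open whether swapping these groups changes toxicity at all.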